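The source may hold more compounds than are shown below. What is called first, only, known or untested is meant among the compounds shown, and "the series" means these compounds.

The three measured compounds share one core: compound 1 `COc1ccc(Nc2cc(C)nc(SCc3nc4ccccc4[nH]3)n2)cc1`, compound 2 `Cc1cc(Nc2ccc(Cl)cc2)nc(SCc2nc3ccccc3[nH]2)n1` and compound 3 `Cc1cc(NCCO)nc(SCc2nc3ccccc3[nH]2)n1`. In a functional assay on ECa-109 cells (Homo sapiens) for cytotoxicity, read by MTT assay, with a stated time of 72 h (a higher number here means a weaker inhibitor, a lower number a stronger inhibitor), compound 1 gives 69800 nM. Compound 2 gives 20400 nM in this assay. Compound 3 reaches only the limit of this assay, > 100000 nM, which is a limit of the assay and not a number. Among the measured steps, a 3.4-fold lower number from compound 1 to compound 2 (0.53 log units; beyond the scatter), while an at least 1.4-fold higher number from compound 1 to compound 3 (0.15 log units; that floor lies within the scatter) and an at least 4.9-fold higher number from compound 2 to compound 3 (0.69 log units; beyond the scatter), so compound 3 is the one of the three that rests at the limit (the limit of > 100000 nM in this assay, at which 1 of the 3 values shown sits).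

Compound 4 `Cc1cc(NNC(N)=S)nc(SCc2nc3ccccc3[nH]2)n1` differs from compound 3 by a group of 4 heavy atoms (1 carbon, 2 nitrogen, 1 sulfur; no ring) in place of a group of 3 heavy atoms (2 carbon, 1 oxygen; no ring), on a nitrogen on an aromatic ring. Among the measured compounds shown here, no measured step exchanges one such small chain for another; the two steps that end at compound 3 both remove an aryl group, and they give no guidance on whether a second small chain would shift the number. The step from compound 3 to compound 4 is therefore expected to be a number no higher from compound 3 to compound 4 (the limit leaves the size open), that is, no change beyond the scatter, with a fair chance that compound 4 also stops at the limit. For compound 4 in this assay the estimated value is 100000 nM, within a range from 30000 nM to 300000 nM.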

Compound 4, half-maximal inhibitory concentration: > 100000 nM
Compound 4 gave a limit, no number; the forecaster's own chance of this, stated with the estimate: 60%; the middle value lies on the limit itself.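

Exchanging the 4-chlorophenyl group on a nitrogen on an aromatic ring for the new chain gives an at least 4.9-fold higher number from compound 2 to compound 4 (0.69 log units; beyond the scatter) in this assay, so a second chain with no ring, and not the 2-hydroxyethyl group alone, comes with a step beyond the scatter; exchanging the 4-methoxyphenyl group gives an at least 1.4-fold higher number from compound 1 to compound 4 (0.15 log units; that floor lies within the scatter), and that floor settles nothing for this pair. The step between the two chains themselves cannot be read, as both values are limits, so the data do not say which chain, if either, is the better one at this position. What compound 4 adds is a second chain of a different make-up that gives no number in this assay, which widens the set of compounds at the ceiling: the limit of > 100000 nM in this assay, at which 2 of the 4 values shown sit.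

The compounds shown leave open whether any group on this nitrogen without a ring can bring the number down from the limit, for instance a simple amine, a carboxylic acid or a longer chain. They also leave open how a plain phenyl group would compare with the two substituted aryl groups.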